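A Chlorophenyl Replaces a Methylphenyl in an Amine Oxidase Series

The source may report more compounds than this note shows. Statements on the series, on what has been measured and on what is new or still open speak of the compounds shown alone.

Compound 1 `C#CCNC1CCc2c(SCc3ccc(Cl)c(Cl)c3)cccc21` gives 74 nM in an ADME assay on isolated protein for inhibition of Amine oxidase [flavin-containing] B (Homo sapiens); a higher number here means a weaker inhibitor, a lower number a stronger inhibitor. Compound 2 `C#CCNC1CCc2c(SCc3ccc(C)cc3)cccc21` gives 320 nM.

Compound 2 thus holds the higher of the two numbers in this assay, and its gap to compound 1 lies beyond the scatter. Compound 3 `C#CCNC1CCc2c(SCc3cccc(Cl)c3)cccc21` differs from compound 2 in one place: 3-chlorophenyl in place of 4-methylphenyl on a saturated chain carbon bound to a sulfur. Among the measured compounds shown here, no measured pair shows this step, so its size is a matter of expectation. Given that compound 1 gives 74 nM, compound 3 is expected to move downward, the step of a 2.1-fold lower number from compound 2 to compound 3 (0.33 log units; beyond the scatter) being modest but beyond the scatter. Compound 3 is estimated at 150 nM, within 50 nM to 450 nM.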

Compound 3, half-maximal inhibitory concentration: 1090 nM
Compound 3: the middle estimate sits 7.3-fold (0.86 log units) below what was measured; measured number outside the range, above it.
By their numbers in this assay, from the lowest: compound 1; then compound 2; then compound 3.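

In this assay, a single chloro on the phenyl ring does not by itself give a lower number: 3-chlorophenyl in place of 4-methylphenyl brings a 3.4-fold higher number from compound 2 to compound 3 (0.53 log units; beyond the scatter). Hydrogen in place of chloro on an aromatic carbon brings a 15-fold higher number from compound 1 to compound 3 (1.17 log units; beyond the scatter), so the low number of compound 1 is lost when that one chloro goes. Nothing available explains either step. The compounds shown leave open how a fluoro, a methoxy or an amine on this phenyl ring would read, and whether a longer chain between the sulfur and the ring would shift the number.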